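Small Change on a Side Chain

A few compounds are considered here, and "the series" means these few. Any claim that something is new, unique, unknown or untested is made for them only; others in the source may bear on it.

Measured so far in a physicochemical assay for solubility (a higher number here means a more soluble compound, a lower number a less soluble compound), for two compounds:
Compound 1 `COC(=O)c1ccc2oc(=S)n(C(=O)CCc3ccccc3)c2c1` gives 200000 nM in this test
Compound 2 `CCC(=O)n1c(=S)[nH]c2ccccc21` gives 180000 nM in this test

Compound 2 at 180000 nM and compound 1 at 200000 nM lie within the usual scatter of each other, so neither can be ranked ahead of the other on these numbers. The two differ in more than one place, and still their values do not separate.

The unmeasured compound 3 `CC(=O)n1c(=S)[nH]c2ccccc21` differs from compound 2 by hydrogen in place of methyl on a saturated chain carbon bound to a carbonyl carbon with hydrogen in place of methyl on a saturated chain carbon bound to a carbonyl carbon. This turns propanoyl into acetyl. Among the measured compounds shown here, no pair of measured compounds differs in one place only, so the data offer no direct guide to this change.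

With compound 2 at 180000 nM as the starting point, no shift beyond the scatter is expected in this assay for this change. The estimated step of a 1.1-fold higher number from compound 2 to compound 3 (0.02 log units; within the scatter) is accordingly small. For compound 3 the estimated value is 190000 nM with 110000 nM to 300000 nM as its expected range.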

Compound 3, solubility: 460000 nM
For compound 3 the middle estimate is 2.4-fold (0.38 log units) below the measured one, outside the stated range (above it).
By their numbers in this assay, from the lowest: compounds 2 and 1 (each within the scatter of the next); then compound 3.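

Among the compounds shown here, replacing propanoyl with acetyl, with hydrogen in place of methyl on a saturated chain carbon bound to a carbonyl carbon, gives the first single-place comparison in this assay, and it produces a 2.6-fold higher number from compound 2 to compound 3 (0.41 log units; beyond the scatter) as a modest change. For the compounds shown here, this shows that the number can respond to a change at this position, which the earlier compounds could not show without a pair differing in one place. The change removes only 1 carbon, with no ring, net charge, hydrogen-bond donor or hydrogen-bond acceptor leaving or entering, but no accompanying measurement explains why the number rises.

This single step does not show whether a longer chain, such as butanoyl, would fall close to compound 2 or whether an amine or a carboxylic acid on the same chain carbon would shift the number further. It also leaves open whether the same change from propanoyl to acetyl would produce a step of similar size on the core of compound 1, where the substituents differ.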